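From an Aromatic Ring to a Short Chain on the Same Nitrogen

A few compounds are considered here, and "the series" means these few. Any claim that something is new, unique, unknown or untested is made for them only; others in the source may bear on it.

Three compounds sharing one core were tested in a functional assay on cells (T-cell, Mus musculus) for inhibition; a higher number here means a weaker inhibitor, a lower number a stronger inhibitor. Compound 1 `CC(=O)Oc1cccc(/C=C/C(=O)Nc2ccc3c(c2)COC3=O)c1` gives 30 nM. Compound 2 `CC(C)c1ccc(/C=C/C(=O)Nc2ccc3c(c2)COC3=O)cc1` gives 1590 nM. Compound 3 `Cc1ccc(NC(=O)Nc2ccc3c(c2)COC3=O)cc1` gives 2670 nM, the highest of the three numbers; compound 2 sits within the scatter of it, so those two cannot be ordered, while compound 1 lies far below both, beyond the scatter.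

Compound 4 `CCCNC(=O)Nc1ccc2c(c1)COC2=O` has not yet been measured. It differs from compound 3 in one place: propyl in place of 4-methylphenyl on an amide-type nitrogen. Going by the values given here, no measured pair in this set shows a move of this kind, so the expectation rests on the structural change alone. With the six-membered aromatic ring gone from the amide-type nitrogen and only a propyl in its place, an upward step is expected in this assay, beyond the scatter, toward a weaker inhibitor: a 3.0-fold higher number from compound 3 to compound 4 (0.48 log units; beyond the scatter). Compound 4 is therefore estimated at 8000 nM, within a range from 2000 nM to 30000 nM.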

Compound 4, half-maximal inhibitory concentration: 58100 nM
For compound 4 the middle estimate is 7.3-fold (0.86 log units) below the measured one; the whole stated range lies below it.
By their numbers in this assay, from the lowest: compound 1; then compounds 2 and 3 (each within the scatter of the next); then compound 4.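

Going from the 4-methylphenyl to propyl on the amide-type nitrogen gives a 22-fold higher number from compound 3 to compound 4 (1.34 log units; beyond the scatter) in this assay, a large step toward a weaker inhibitor. Going by these compounds alone, this is the first single-place comparison in the set, and it shows that the group on this nitrogen strongly affects the number, with the ring-free propyl faring far worse than the 4-methylphenyl. Nothing available explains the size of this step.

The step removes the aromatic ring and shortens the group in one move, so the compounds shown cannot separate those two changes. As far as these compounds go, whether a cyclohexyl, a plain phenyl or a longer chain such as hexyl on this nitrogen would stay close to compound 3 remains open, as does the effect of an amine or a carboxylic acid carried on the chain.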